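Bromo in place of chloro: compound 2 to compound 3

A few compounds are considered here, and "the series" means these few. Any claim that something is new, unique, unknown or untested is made for them only; others in the source may bear on it.

Among the measured compounds shown here, compound 2 `CC(C)(C)N(NC(=O)c1cccc(Cl)c1)C(=O)c1ccccc1Cl` gives 155 nM in an assay on cells for agonist activity at ecdysone receptor (Bombyx mori), read by a luciferase reporter, with a stated time of 24 h (on this read-out lower numbers stand for an effect already at smaller amounts and higher numbers for an effect only at larger amounts of compound), and stands highest of the two numbers measured so far; its nearest neighbour, compound 1 `CC(C)(C)N(NC(=O)c1ccccc1)C(=O)c1ccccc1Cl`, gives 75.9 nM. For the measured compounds named here, the only measured step, a 2.0-fold higher number from compound 1 to compound 2 (0.31 log units; beyond the scatter), put chloro where hydrogen stood. Compound 3 `CC(C)(C)N(NC(=O)c1cccc(Br)c1)C(=O)c1ccccc1Cl` differs from compound 2 by bromo in place of chloro on an aromatic carbon. Going by the values given here, no measured step exchanges one halogen for another, so the hydrogen-to-chloro step bears on it only loosely. For compound 3 a step within the scatter is expected, a 1.0-fold higher number from compound 2 to compound 3 (0.01 log units; within the scatter). Compound 3 is therefore estimated at 160 nM, with a range from 80 nM to 320 nM.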

Compound 3, half-maximal effective concentration: 191 nM
Beside the measured number, compound 3's estimate is 1.2-fold (0.08 log units) below it; the range from low to high includes it.
By their numbers in this assay, from the lowest: compound 1; then compounds 2 and 3 (each within the scatter of the next).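

Exchanging the halogen at this position in this assay gives a 1.2-fold higher number from compound 2 to compound 3 (0.09 log units; within the scatter) and so does not separate 3-chlorophenyl from 3-bromophenyl. Bromo in place of hydrogen gives a 2.5-fold higher number from compound 1 to compound 3 (0.40 log units; beyond the scatter) and, like chloro, stands beyond the scatter on the side of higher numbers, so this direction holds for both halogens shown. Nothing measured gives a reason for either step. Still open, going by these compounds, is whether the direction extends beyond chloro and bromo to fluoro, or to a non-halogen such as methoxy or an amine at this position.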